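A Bromofuran Variant of a Weak Growth Inhibitor

The source may hold more compounds than are shown below. What is called first, only, known or untested is meant among the compounds shown, and "the series" means these compounds.

Within the data shown here, compound 1 `COc1ccc(CNC(=O)/C(C#N)=C/c2ccc(C)o2)cc1` is a weak inhibitor in a functional assay on HT-29 cells (Homo sapiens) for inhibition, read by MTT assay, with a stated time of 72 h; a lower number here means a stronger inhibitor of growth, a higher number a weaker inhibitor of growth; compound 1 gives 92000 nM, the highest of the two numbers known. Compound 2 `COc1ccc(CNC(=O)/C(C#N)=C/c2ccc(-c3ccccc3)o2)cc1` gives 56000 nM, and a 1.6-fold lower number from compound 1 to compound 2 (0.22 log units; within the scatter). Compound 3 `COc1ccc(CNC(=O)/C(C#N)=C/c2cc(Br)co2)cc1` carries 4-bromofuran-2-yl in place of 5-methylfuran-2-yl on a double-bonded chain carbon bound to a double-bonded chain carbon. Among the measured compounds shown here, the only measured step, from compound 1 to compound 2, also exchanged one group on the same ring and stayed within the scatter, so no move beyond the scatter is expected in this assay; the expected step is a 1.2-fold lower number from compound 1 to compound 3 (0.06 log units; within the scatter). Compound 3 is expected to give 80000 nM, between 30000 nM and 200000 nM.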

Compound 3, concentration for 50% growth inhibition: 36000 nM
Beside the measured number, compound 3's estimate is 2.2-fold (0.35 log units) above it; the measured number falls inside the stated range.
By their numbers in this assay, from the lowest: compounds 3, 2 and 1 (each within the scatter of the next, the first and the last beyond it).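

In this assay, 4-bromofuran-2-yl in place of 5-methylfuran-2-yl gives a 2.6-fold lower number from compound 1 to compound 3 (0.41 log units; beyond the scatter), a modest step, but the only one here that lies beyond the scatter. It shows that the number can move at this place on a double-bonded chain carbon even when both groups have the same count of heavy atoms and the same hydrogen-bond counts. No available data account for this step. Still open, on these data alone, is whether the bromine itself or its location on the ring matters, since both differ from the methyl of compound 1. An amine or a carboxylic acid on the same ring could also behave quite differently.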